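The compounds below may be only part of what the source reports. "The series", "measured", "known", "first", "only" and "open" are said of these compounds alone.

Compound 2 `Cc1ccc(S(=O)(=O)c2cc3cnc(Nc4cccc5cccnc45)nc3n(C)c2=O)cc1` is the weakest of three compounds built on one shared core. In a functional assay on DU-145 cells (Homo sapiens) for inhibition, read by trypan blue exclusion, with a stated time of 72 h (a higher number here means a weaker inhibitor, a lower number a stronger inhibitor), compound 2 gives 10000 nM, the highest number of the three. Compound 1 `Cn1c(=O)c(S(=O)(=O)c2ccc(F)cc2F)cc2cnc(Nc3cccc4[nH]ccc34)nc21` gives 750 nM, and compound 3 `Cn1c(=O)c(S(=O)(=O)c2ccc(F)cc2)cc2cnc(Nc3cnc4[nH]ccc4c3)nc21` gives 500 nM; both gaps to compound 2 lie beyond the usual scatter. Compound 4 `COc1ccc(Nc2ncc3cc(S(=O)(=O)c4ccc(C)cc4)c(=O)n(C)c3n2)cc1` has not yet been measured. It differs from compound 2 in one place: 4-methoxyphenyl in place of quinolin-8-yl on a nitrogen on an aromatic ring. Among the compounds with values here, no two measured compounds differ in a single place, so no measured step shows what this change does. A modest move toward a lower number is expected, with a 2.0-fold lower number from compound 2 to compound 4 (0.30 log units; within the scatter) as the estimated step. Compound 4 is therefore estimated at 5000 nM, with a likely range from 1500 nM to 15000 nM.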

Compound 4, half-maximal inhibitory concentration: 100000 nM
Estimate against measurement, compound 4: 20-fold (1.30 log units) below, and the stated range ends below it.
By their numbers in this assay, from the lowest: compounds 3 and 1 (each within the scatter of the next); then compound 2; then compound 4.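

Within the data shown here, this is the first comparison in the set that changes only one place: in this assay, 4-methoxyphenyl in place of quinolin-8-yl on a nitrogen on an aromatic ring gives a 10-fold higher number from compound 2 to compound 4 (1.00 log units; beyond the scatter). The group at this position can therefore shift the number well beyond the scatter, and here the change makes the inhibitor weaker. No measurement shown accounts for this loss.

Going by these compounds, whether the step comes from adding the methoxy group or losing the second ring stays open; the change does both at once. A plain phenyl or an aminophenyl group on this nitrogen could begin to separate these.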